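Swapping Methyl for Amino on the Shared Core

The source may report more compounds than this note shows. Statements on the series, on what has been measured and on what is new or still open speak of the compounds shown alone.

Measured compounds:
compound 1 `Cc1c(F)c(N)c2c(=O)cc(-c3ccc(N)c(F)c3)oc2c1F`, > 100000 nM
compound 2 `COc1c(F)c(N)c2c(=O)cc(-c3ccc(N)c(F)c3)oc2c1F`, 34000 nM
compound 3 `Nc1ccc(-c2cc(=O)c3c(N)c(F)c(Cl)c(F)c3o2)cc1F`, > 100000 nM

In a functional assay on HeLa cells (Homo sapiens) for cytotoxicity, read by neutral red uptake, with a stated time of 3 days (a lower number here means a stronger inhibitor, a higher number a weaker inhibitor), the value of compound 1 is a limit of the assay, not a number. The value of compound 3 is likewise a limit. Compound 1 therefore stands at the weak end, on (the limit of > 100000 nM in this assay, at which 2 of the 3 values shown sit), with only compound 2 giving a readable number. Compound 4 `Nc1ccc(-c2cc(=O)c3c(N)c(F)c(N)c(F)c3o2)cc1F` differs from compound 1 by amino in place of methyl on an aromatic carbon. Two measured steps start from compound 1: an at least 2.9-fold lower number from compound 1 to compound 2 (0.46 log units; beyond the scatter), and a step that the two limits leave unreadable from compound 1 to compound 3. A polar group entering at this place gave a readable gain once and an unreadable outcome once, so the expected step is an at least 1.6-fold lower number from compound 1 to compound 4 (0.22 log units; that floor lies within the scatter), a small one at best. Compound 4 is estimated at 60000 nM, between 20000 nM and 200000 nM.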

Compound 4, half-maximal inhibitory concentration: 19000 nM
Estimate against measurement, compound 4: 3.2-fold (0.50 log units) above, and the stated range ends above it.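

In this assay, amino at this place gives an at least 5.2-fold lower number from compound 1 to compound 4 (0.72 log units; beyond the scatter), and replacing chloro gives an at least 5.2-fold lower number from compound 3 to compound 4 (0.72 log units; beyond the scatter). Compounds 2 and 4 now both leave the weak end, so the readable gain seen with methoxy is no longer a single case, while a 1.8-fold lower number from compound 2 to compound 4 (0.25 log units; within the scatter) does not separate amino from methoxy. Both steps from the weak end are floors, since each starts from a limit rather than a number: the limit of > 100000 nM in this assay, at which 2 of the 4 values shown sit.

As far as these compounds go, whether a hydroxyl or a dimethylamino group here would give a lower number remains open.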